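The source may hold more compounds than are shown below. What is called first, only, known or untested is meant among the compounds shown, and "the series" means these compounds.

Measured compounds:
Compound 1, `Nc1ccccc1CN1CC[C@H](O[C@@H]2O[C@H](CO[C@@H]3O[C@H](CO)[C@@H](O)[C@H](O)[C@H]3O)[C@@H](O)[C@H](O)[C@H]2O)C1=O`: 42800 nM
Compound 2, `Nc1ccccc1CN1CC[C@@H](O)C1=O`: 42300 nM

Of the compounds shown here, two have been measured in a functional assay on HL-60 cells (Homo sapiens) for cytotoxicity, read by trypan blue exclusion; on this read-out higher numbers stand for weaker inhibition and lower numbers for stronger inhibition. Compound 1, `Nc1ccccc1CN1CC[C@H](O[C@@H]2O[C@H](CO[C@@H]3O[C@H](CO)[C@@H](O)[C@H](O)[C@H]3O)[C@@H](O)[C@H](O)[C@H]2O)C1=O`, gives 42800 nM, and compound 2, `Nc1ccccc1CN1CC[C@@H](O)C1=O`, gives 42300 nM. Compound 2 holds the lowest of the two numbers, but its nearest neighbour, compound 1, sits within the scatter, so the two cannot be told apart on this read-out.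

Compound 3, `Nc1ccccc1CN1CC[C@H](O)C1=O`, has not yet been measured. The change from compound 2 to compound 3 is the two compounds have the same atoms and bonds and differ only in configuration as drawn: 1 of 1 stereo elements differ; a stereocentre at a saturated ring carbon is drawn R in compound 2 and S in compound 3. Among the compounds with values here, no measured pair shows what such an inversion does here, and the two measured compounds sit close together on this assay. The author therefore expects no step beyond the scatter, an estimated change of a 1.0-fold lower number from compound 2 to compound 3 (0.00 log units; within the scatter). Compound 3 is expected to give about 42000 nM in this assay, within a range from 18000 nM to 100000 nM.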

Compound 3, half-maximal inhibitory concentration: 42300 nM
The estimate for compound 3 lay 1.0-fold (0.00 log units) below the measured number, and the stated range covers the measured number.
By their numbers in this assay, from the lowest: compounds 2, 3 and 1 (each within the scatter of the next).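

In this assay, inverting the stereocentre at a saturated ring carbon gives no change at the digits printed from compound 2 to compound 3 (within the scatter). Within the data shown here, this is the first pair in the set that differs in one place, and it shows that this read-out does not separate the R drawing from the S drawing at this position. The comparison isolates a single feature: the fact that compounds 2 and 3 differ only in the configuration as drawn

The compounds shown leave open whether a carboxylic acid or a fluorine atom at that saturated ring carbon would give a number beyond the scatter of compound 2 and compound 3. They also leave open whether the same inversion would read alike in the larger compound 1, whose other configuration at this carbon has no partner here.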